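Aryl urea variation on the shared core

This account rests on a few compounds, and the source may have more. Where it says the series, first, only, none or still open, it means among the compounds named here.

Compound 1 `CCOc1ccc(NC(=O)Nc2cccc(CNc3nccnc3Cl)c2)cc1` gives 7050 nM in a functional assay on HepG2 cells (Homo sapiens) for antiproliferative activity, read by MTT assay, with a stated time of 48 h (a lower number here means a stronger inhibitor, a higher number a weaker inhibitor), the lowest of the three numbers available, though its gaps to the other two lie within the scatter. Compound 2 `O=C(Nc1cccc(Cl)c1)Nc1cccc(CNc2nccnc2Cl)c1` gives 9140 nM and compound 3 `Cc1ccc(NC(=O)Nc2cccc(CNc3nccnc3Cl)c2)cc1C` gives 10700 nM in this assay. The steps among them are small: a 1.3-fold higher number from compound 1 to compound 2 (0.11 log units; within the scatter), a 1.5-fold higher number from compound 1 to compound 3 (0.18 log units; within the scatter) and a 1.2-fold higher number from compound 2 to compound 3 (0.07 log units; within the scatter).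

Compound 4 `O=C(Nc1cccc(CNc2nccnc2Cl)c1)Nc1ccc(Cl)c(Cl)c1` differs from compound 1 by 3,4-dichlorophenyl in place of 4-ethoxyphenyl on an amide-type nitrogen. The two measured steps from compound 1 bear on this, since each also replaces the 4-ethoxyphenyl with another substituted phenyl on the same amide-type nitrogen, and neither moved the number beyond the scatter; the 3-chlorophenyl case, a 1.3-fold higher number from compound 1 to compound 2 (0.11 log units; within the scatter), is the nearest comparison to the 3,4-dichlorophenyl. No step beyond the scatter is therefore expected in this assay, with at most a slight lean toward a higher number. Compound 4 is estimated at 9500 nM, within a range of 4000 nM to 22000 nM. The expected step is then a 1.3-fold higher number from compound 1 to compound 4 (0.13 log units; within the scatter).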

Compound 4, half-maximal inhibitory concentration: 6170 nM
Estimate against measurement, compound 4: 1.5-fold (0.19 log units) above, within the range that was stated.
By their numbers in this assay, from the lowest: compounds 4, 1, 2 and 3 (each within the scatter of the next).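

The 3,4-dichlorophenyl holds no hydrogen-bond acceptor where the 4-ethoxyphenyl holds one, yet the step on this amide-type nitrogen stays within the scatter (a 1.1-fold lower number from compound 1 to compound 4 (0.06 log units; within the scatter)). Chloro in place of hydrogen on an aromatic carbon of the 3-chlorophenyl also stays within the scatter (a 1.5-fold lower number from compound 2 to compound 4 (0.17 log units; within the scatter)), as does 3,4-dichlorophenyl in place of 3,4-dimethylphenyl (a 1.7-fold lower number from compound 3 to compound 4 (0.24 log units; within the scatter)), so all four substituted phenyl groups now sit within the scatter of one another at this position. Nothing measured on hand accounts for this lack of separation.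

Open, going by these compounds, is whether a carboxylic acid or a dimethylamino group on this phenyl, or a cyclohexyl in its place on the amide-type nitrogen, would give a step beyond the scatter. Also open, on these data alone, is whether any change to the shared core would do so.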